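Amine substituent changes on the shared diaryl ether core

The source may hold more compounds than are shown below. What is called first, only, known or untested is meant among the compounds shown, and "the series" means these compounds.

Measured in a functional assay on DLD-1 cells (Homo sapiens) for inhibition, read by MTT assay, with a stated time of 72 h; a higher number here means a weaker inhibitor, a lower number a stronger inhibitor:
Compound 1, `COc1cc(Oc2cccc(Nc3ccccc3)c2)cc(OC)c1CNCc1ccc(Cl)cc1`, gives 3740 nM.
Compound 2, `COc1cc(Oc2cccc(Nc3ccccc3)c2)cc(OC)c1CNC1CC1`, gives only a limit of the assay, > 20000 nM.
Compound 3, `CNCc1c(OC)cc(Oc2cccc(Nc3ccccc3)c2)cc1OC`, gives 11900 nM.

Compound 2 thus stands at a limit of this assay and has no number of its own; of the values shown it is the one sitting at the limit of > 20000 nM in this assay, at which 1 of the 3 values shown sits. Compound 4, `COc1ccc(CNCc2c(OC)cc(Oc3cccc(Nc4ccccc4)c3)cc2OC)cc1`, differs from compound 2 by 4-methoxybenzyl in place of cyclopropyl on an amine nitrogen. The step bearing most directly on this is an at least 5.3-fold higher number from compound 1 to compound 2 (0.72 log units; beyond the scatter), which ran from 4-chlorobenzyl to cyclopropyl; the present change runs the other way, from cyclopropyl to 4-methoxybenzyl. a 3.2-fold higher number from compound 1 to compound 3 (0.50 log units; beyond the scatter) likewise shows 4-chlorophenyl on the chain carbon giving a lower number than hydrogen. A lower number, beyond the scatter, is therefore expected: an at least 4.0-fold lower number from compound 2 to compound 4 (0.60 log units; beyond the scatter). Compound 4 is estimated at about 5000 nM, within 2000 nM to 15000 nM.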

Compound 4, half-maximal inhibitory concentration: 1910 nM
Compound 4: the middle estimate sits 2.6-fold (0.42 log units) above what was measured; the measured number lies below the stated range.
By their numbers in this assay, from the lowest: compounds 4 and 1 (each within the scatter of the next); then compound 3. At a limit, above all of these: compound 2.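

In this assay, compound 2 stands at a limit of the assay, not at a number of its own: the limit of > 20000 nM in this assay, at which 1 of the 4 values shown sits. The aromatic 4-methoxybenzyl group in place of cyclopropyl on the amine nitrogen gives an at least 10-fold lower number from compound 2 to compound 4 (1.01 log units; beyond the scatter), and the comparison with the methyl amine gives a 6.2-fold lower number from compound 3 to compound 4 (0.79 log units; beyond the scatter). Methoxy in place of chloro on the aromatic carbon gives a 2.0-fold lower number from compound 1 to compound 4 (0.29 log units; within the scatter), so this assay does not separate the two substituted benzyl amines. Still open, from the compounds shown here alone, is whether an unsubstituted benzyl or a phenethyl group on the amine nitrogen would match the values of compound 1 and compound 4.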